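The compounds below may be only part of what the source reports. "The series", "measured", "known", "first", "only" and "open" are said of these compounds alone.

Measured so far in this assay:
compound 1 `CC(=O)c1cccc(-c2ccc(C(=O)N(Cc3cccc(OCCCCCC(=O)O)c3)C(C)C)cc2)c1`: > 26000 nM
compound 2 `CCOC(=O)CCCCCOc1cccc(CN(C(=O)c2ccc(-c3cccc4ccccc34)cc2)C(C)C)c1`: > 26000 nM
compound 3 `CCOC(=O)CCCCCOc1cccc(CN(C(=O)c2ccc(-c3cccc(-c4ccccc4)c3)cc2)C(C)C)c1`: > 26000 nM

In an ADME assay on BJ cells (Homo sapiens) for cytotoxicity, read by CellTiter-Glo and resazurin assay, with a stated time of 72 h (on this read-out lower numbers stand for an effect already at smaller amounts and higher numbers for an effect only at larger amounts of compound), compound 3 stands at a limit, not at a number: its reading of > 26000 nM is a limit of the assay. Compound 2 likewise gives only a limit in this assay, > 26000 nM. Compound 1 too gives only a limit, > 26000 nM. For the measured compounds named here, all three readings therefore sit together on (the limit of > 26000 nM in this assay, at which 3 of the 3 values shown sit), and the one step between measured neighbours, a step that the two limits leave unreadable from compound 2 to compound 3, cannot be read in size or direction.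

Compound 4 `CCOC(=O)CCCCCOc1cccc(CN(C(=O)c2ccc(-c3cccc(C(C)=O)c3)cc2)C(C)C)c1` differs from compound 3 by acetyl in place of phenyl on an aromatic carbon. Going by the values given here, no measured step bears directly on this exchange, and the only measured step is itself unreadable. Because every measured compound rests on (the limit of > 26000 nM in this assay, at which 3 of the 3 values shown sit), compound 4 is expected to sit at that limit as well, so that the expected step that the limit leaves unreadable from compound 3 to compound 4 from compound 3 is none beyond the scatter. Compound 4 is estimated at 30000 nM, within a range from 13000 nM to 100000 nM.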

Compound 4, half-maximal effective concentration: > 26000 nM
Compound 4: only a limit was reported; the forecaster's own chance of this, stated with the estimate: 85%; the middle value lies beyond the limit too.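

Compound 4 gives only a limit, as do compound 1, compound 2 and compound 3, so none of the steps to compound 4 can be read in this assay: the limit of > 26000 nM in this assay, at which 4 of the 4 values shown sit.

The compounds shown leave open which change in structure, if any, would bring a measurable reading in this assay.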